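Nitro for methoxy on the ester aryl of compound 1

A few compounds are considered here, and "the series" means these few. Any claim that something is new, unique, unknown or untested is made for them only; others in the source may bear on it.

Compound 1 `COc1cccc(C(=O)Oc2cc3c(cc2C)[C@@H](C(C)C)CC=C3C)c1` is the reference. In a functional assay on U-251 cells (Homo sapiens) for antiproliferative activity, read by sulforhodamine B assay, with a stated time of 48 h, tested at 50 uM (a higher number here means more inhibition at the concentration tested (going by the name of the read-out), a lower number less inhibition), compound 1 gives "not active" (no number reported), with no number attached, so it stands in the series only with a reported verdict and without a value to rank it. Compound 2 `Cc1cc2c(C(C)C)ccc(C)c2cc1OC(=O)c1cccc(C(F)(F)F)c1` likewise gives "not active" (no number reported) in this assay. Compound 3 `Cc1cc2c(C(C)C)ccc(C)c2cc1OC(=O)c1ccc([N+](=O)[O-])cc1` carries a nitro group on the ester aryl but sits on a different core from compound 1; in this assay compound 3 gives 100%, the only numbered result so far.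

Compound 4 `CC1=CC[C@H](C(C)C)c2cc(C)c(OC(=O)c3cccc([N+](=O)[O-])c3)cc21` differs from compound 1 at one place: nitro in place of methoxy on an aromatic carbon. Going by the values given here, no measured pair shows this exact change, so the size of the step is open. Among the compounds with values here, compound 3 with its nitro group is the one compound with a numbered inhibition, while compound 1 and compound 2 without it are reported as not active, which points to a higher inhibition in this assay beyond the scatter, though the core also differs between compound 3 and compound 4. The estimate for compound 4 in this assay is 55%, expected between 10% and 100%.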

Compound 4, a percentage reported as inhibition, at one concentration (the size of the read-out at that concentration, not a potency): 44%
Compound 4: middle estimate off by 11 percentage points, on the high side; measured number inside the range.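

In this assay compound 1 gives "not active" (no number reported) and compound 4 gives 44% so no step can be read between them. The compounds shown leave open how large the change from methoxy to nitro is on the shared core. No evidence on hand bears on this result.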